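Swapping 3-(trifluoromethoxy)phenyl for 2-(trifluoromethoxy)phenyl on the sulfonyl sulfur

The compounds below may be only part of what the source reports. "The series", "measured", "known", "first", "only" and "open" are said of these compounds alone.

In a functional assay on VCaP cells (Homo sapiens) for antiproliferative activity, read by propidium iodide staining, with a stated time of 96 h (a lower number here means a stronger inhibitor, a higher number a weaker inhibitor), compound 1 `CC(O)(CS(=O)(=O)c1ccc(C(F)(F)F)cc1)C(=O)Nc1ccc(S(F)(F)(F)(F)F)cc1` gives 27700 nM and compound 2 `CC(O)(CS(=O)(=O)c1cccc(OC(F)(F)F)c1)C(=O)Nc1ccc(S(F)(F)(F)(F)F)cc1` gives 23700 nM. Among the compounds with values here, these two values lie within the scatter of each other, so compound 2 cannot be separated from the only other measured compound. Compound 3 `CC(O)(CS(=O)(=O)c1ccccc1OC(F)(F)F)C(=O)Nc1ccc(S(F)(F)(F)(F)F)cc1` has the same atoms as compound 2, joined differently: 2-(trifluoromethoxy)phenyl in place of 3-(trifluoromethoxy)phenyl on a sulfonyl sulfur. It carries 2-(trifluoromethoxy)phenyl in place of 3-(trifluoromethoxy)phenyl on a sulfonyl sulfur. Within the data shown here, only one measured step bears on this change, since it also exchanges the group on that sulfur: a 1.2-fold lower number from compound 1 to compound 2 (0.07 log units; within the scatter). Among the measured compounds shown here, no compound bearing 2-(trifluoromethoxy)phenyl has been measured, so the evidence is thin. Going by that single step, no change beyond the scatter is expected in this assay. The expected step is a 1.0-fold higher number from compound 2 to compound 3 (0.01 log units; within the scatter). Compound 3 is estimated at 24000 nM, with an expected range of 12000 nM to 45000 nM.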

Compound 3, half-maximal inhibitory concentration: 19900 nM
Compound 3: middle estimate off by 1.2-fold (0.08 log units), on the high side; the measured number falls inside the stated range.
By their numbers in this assay, from the lowest: compounds 3, 2 and 1 (each within the scatter of the next).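

The result in this assay extends the picture from one exchange of group on the sulfonyl sulfur to an exchange that keeps the same atoms: 2-(trifluoromethoxy)phenyl in place of 3-(trifluoromethoxy)phenyl gives a 1.2-fold lower number from compound 2 to compound 3 (0.08 log units; within the scatter) and so leaves the number within the scatter. Set against 4-(trifluoromethyl)phenyl, the same group gives a 1.4-fold lower number from compound 1 to compound 3 (0.14 log units; within the scatter) and is again within the scatter, so the three groups tried on this sulfur cannot be told apart. No measurement offered here accounts for this result.

From the compounds shown here alone, it remains open whether any group on this sulfur can shift the number beyond the scatter, for instance a phenyl ring bearing an amine or a carboxylic acid, or a saturated chain in place of the ring. Going by these compounds, what a change elsewhere in the shared core would do also remains open.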